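A few compounds are considered here, and "the series" means these few. Any claim that something is new, unique, unknown or untested is made for them only; others in the source may bear on it.

Among the measured compounds shown here, compound 1 `CC(C)(CC(=O)Nc1ccc(F)c(C(F)(F)F)c1)C(=O)O` is one of three compounds measured in an ADME assay on microsomes from liver (Mus musculus) for metabolic stability, using NADPH, with a stated time of 60 min; on this read-out lower numbers stand for slow clearance and higher numbers for fast clearance. In this assay compound 1 gives < 7 uL/min, which is a limit of the assay rather than a number. Compound 2 `CC(C)(C(=O)O)n1c(=O)[nH]c2cc(C(F)(F)F)c(F)cc21` in this assay gives < 7 uL/min, also a limit. Compound 3 `CC(C)(C(=O)O)N1Cc2cc(F)c(C(F)(F)F)cc2NC1=O` in this assay gives < 7 uL/min, again a limit. Compound 1 therefore stands at the floor of the read-out together with the other two (the limit of < 7 uL/min in this assay, at which 3 of the 3 values shown sit), and no ordering among the three can be drawn from these values.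

Compound 4 `CC(C)(NC(=O)Nc1ccc(F)c(C(F)(F)F)c1)C(N)=O` has not yet been measured in this assay. It differs from compound 1 by (1-carbamoyl-1-methylethyl)amino in place of 2-carboxy-2-methylpropyl on a carbonyl carbon: the 2-carboxy-2-methylpropyl group leaves and a (1-carbamoyl-1-methylethyl)amino group enters, on a carbonyl carbon whose other neighbour is an amide-type nitrogen. For the measured compounds named here, no measured step between any two compounds is available here, so the position of compound 1 at its limit is the only guide. The step from compound 1 to compound 4 is expected to be a number no lower from compound 1 to compound 4 (the limit leaves the size open), upward if anything, and not clearly beyond the scatter. Compound 4 is expected to give 7 uL/min in this assay, within a range from 3 uL/min to 20 uL/min.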

Compound 4, intrinsic clearance in a liver preparation (reported as CLH), per the amount of preparation that the assay uses in the Mus musculus assay: 18 uL/min
Beside the measured number, compound 4's estimate is 2.6-fold (0.41 log units) below it; measured number inside the range.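

Among the compounds shown here, the swap of 2-carboxy-2-methylpropyl for (1-carbamoyl-1-methylethyl)amino on a carbonyl carbon is the first change here that the clearance read-out can register, with an at least 2.5-fold higher number from compound 1 to compound 4 (0.41 log units; beyond the scatter). The earlier compounds shown here could show no such movement, as every value was a limit, and most of the series still rests there: the limit of < 7 uL/min in the Mus musculus assay, at which 3 of the 4 values shown sit. In a physicochemical assay for solubility, read by nephelometry, in phosphate buffer, measured as kinetic solubility, at pH 6.5, tested at 10 mg/mL (on this read-out lower numbers stand for lower solubility and higher numbers for higher solubility), compound 1 gives 25 ug/mL and compound 4 gives 50 ug/mL, two values within the usual scatter of each other.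

On these data alone, compound 1 stands at a limit, so the full size of the step stays open. As far as these compounds go, the whole group changes at once, so it also stays open whether the amino link or the carbamoyl carries the step, and how a nitrile or a methyl ester in place of the carbamoyl would read.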